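A Halogen Swap Weighed Against Liver Clearance

The source may hold more compounds than are shown below. What is called first, only, known or untested is meant among the compounds shown, and "the series" means these compounds.

Compound 1 `c1ccc(OCC2[C@H]3CN(Cc4nc5ccccc5s4)C[C@@H]23)cc1`, compound 2 `c1ccc(OCC2[C@H]3CN(Cc4cn5ccccc5n4)C[C@@H]23)cc1` and compound 3 `Cn1c(CN2C[C@@H]3C(COc4cc(F)ccc4F)[C@@H]3C2)nc2ccccc21` were studied in an in vitro ADME assay on microsomes from liver (Homo sapiens) for metabolic stability, tested at 1 uM; a higher number here means faster removal of the compound, a lower number slower removal. For compound 1 the reading is a limit of the assay, < 5.3 mL/min/kg, and the compound is removed no faster than that. For compound 2 no result was reported in this assay, "not determined" (no result reported). For the measured compounds named here, for compound 3 the reading is also a limit of the assay, > 18.7 mL/min/kg, which tells only that this compound is removed at least that quickly. Compound 3 therefore stands at the upper edge of what this assay can resolve, the edge described by the limit of > 18.7 mL/min/kg in this assay, at which 1 of the 3 values shown sits, while compound 1 sits at the opposite edge, described by the limit of < 5.3 mL/min/kg in this assay, at which 1 of the 3 values shown sits. Going by the values given here, no two compounds here differ in a single place, so no measured step is available.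

Compound 4 `Cn1c(CN2C[C@@H]3C(COc4ccc(Cl)cc4)[C@@H]3C2)nc2ccccc21` keeps the whole of compound 3 except for one exchange: 4-chlorophenyl in place of 2,5-difluorophenyl on an oxygen on a saturated carbon. A single halogenated ring replaces another. Without any measured step of this kind to lean on, the expected change is none beyond the usual scatter, so compound 4 is expected to remain near the upper limit, as written in a step that the limit leaves unreadable from compound 3 to compound 4. In this assay compound 4 is estimated at 22 mL/min/kg, with a range from 10 mL/min/kg to 45 mL/min/kg.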

Compound 4, clearance: 6.6 mL/min/kg
Beside the measured number, compound 4's estimate is 3.3-fold (0.52 log units) above it; measured number outside the range, below it.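

For the compounds shown here, this is the first step measured at this position, and it shows that the ring on this oxygen is not a silent place: in this assay, 4-chlorophenyl in place of 2,5-difluorophenyl gives an at least 2.8-fold lower number from compound 3 to compound 4 (0.45 log units; beyond the scatter). Nothing else differs between the two compounds, so this exchange alone is enough to bring the shared structure from the upper limit of the read-out into the range where a single number can be given. That size is only a minimum, and the true gap may be wider, because the reading of compound 3 is a limit of the assay rather than a number: the limit of > 18.7 mL/min/kg in this assay, at which 1 of the 4 values shown sits.

The exchange alters the kind of halogen and its place on the ring together, and the compounds shown do not separate the two, nor do they say why the reading falls. Also open, from the compounds shown here alone, is how a ring such as 4-methoxyphenyl on the same oxygen would behave in this assay, and whether this exchange would give a similar step on the core of compound 1.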